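The source may hold more compounds than are shown below. What is called first, only, known or untested is meant among the compounds shown, and "the series" means these compounds.

Measured so far:
compound 1 `Oc1cc(C(F)(F)F)ccc1-c1nc(-c2ccccc2O)n(-c2ccccc2F)n1` — 63.4%
compound 2 `Oc1cc(C(F)(F)F)ccc1-c1nc(-c2ccccc2O)n(-c2ccc(F)cc2F)n1` — 65.9%

In a functional assay on PC-12 cells (Rattus norvegicus) for cytotoxicity, read by MTT assay, with stated times of 2 h and 24 h, tested at 1 uM (on this read-out lower numbers stand for a weaker effect and higher numbers for a stronger effect at the one concentration tested), compound 2 stands highest of the two numbers, with compound 1 nearest; the two are within the scatter. Compound 3 `Oc1cc(C(F)(F)F)ccc1-c1nc(-c2ccccc2O)n(-c2ccc(Cl)cc2Cl)n1` carries the change (2,4-dichlorophenyl in place of 2,4-difluorophenyl on an aromatic nitrogen). Going by the values given here, the only measured step, a number 2.5 percentage points higher from compound 1 to compound 2 (within the scatter), swaps hydrogen for fluoro on the same ring and stayed within the scatter, so no measured step bears directly on a fluorine-to-chlorine exchange. Nothing in the series points to a shift in this assay beyond the scatter, and the step to compound 3 is expected as a number 0.1 percentage points higher from compound 2 to compound 3 (within the scatter). For compound 3 the estimate is 66%, with a range from 50% to 80%.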

Compound 3, a percentage reported as activity, at one concentration (the size of the read-out at that concentration, not a potency): 69%
The estimate for compound 3 lay 3 percentage points below the measured number; low and high end bracket the measured number.
By their numbers in this assay, from the lowest: compounds 1, 2 and 3 (each within the scatter of the next).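

In this assay, exchanging the halogen itself on the aromatic nitrogen, with 2,4-dichlorophenyl in place of 2,4-difluorophenyl, gives a number 3.1 percentage points higher from compound 2 to compound 3 (within the scatter). With 2,4-dichlorophenyl in place of 2-fluorophenyl, the wider change at this position gives a number 5.6 percentage points higher from compound 1 to compound 3 (within the scatter), so this read-out does not separate these three halogenated phenyl groups. No measurement at hand offers an explanation for this result.

Still open, on these data alone, is how a phenyl bearing an amine or a carboxylic acid would read at this position. As far as these compounds go, replacing the phenyl ring with a simple methyl or a longer alkyl chain is equally open.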